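The compounds below may be only part of what the source reports. "The series", "measured", "known", "first", "only" and "open" are said of these compounds alone.

Compound 3 `CCN(CC)Cc1csc(-c2ccc(N3C[C@H](CNC(=O)c4ccc(Cl)s4)OC3=O)cc2)n1` gives 1030 nM in an assay on isolated protein (plasma) for inhibition of coagulation factor X (Oryctolagus cuniculus); on this read-out higher numbers stand for weaker inhibition and lower numbers for stronger inhibition. Compound 2 `CCNCc1csc(-c2ccc(N3C[C@H](CNC(=O)c4ccc(Cl)s4)OC3=O)cc2)n1` gives 1160 nM and compound 1 `O=C(NC[C@H]1CN(c2ccc(-n3cccc3CN3CCC3)cc2)C(=O)O1)c1ccc(Cl)s1` gives 1520 nM, so all three numbers lie within the scatter of one another and compound 3 stands apart from neither. Compound 4 `O=C(NC[C@H]1CN(c2ccc(-c3nc(CN4CCCCC4)cs3)cc2)C(=O)O1)c1ccc(Cl)s1` differs from compound 3 by piperidin-1-yl in place of diethylamino on a saturated chain carbon bound to an aromatic carbon. Within the data shown here, the one measured step at the amine nitrogen, a 1.1-fold lower number from compound 2 to compound 3 (0.05 log units; within the scatter), stayed within the scatter; the steps of a 1.3-fold lower number from compound 1 to compound 2 (0.12 log units; within the scatter) and a 1.5-fold lower number from compound 1 to compound 3 (0.17 log units; within the scatter) change another place and were also within the scatter. Replacing diethylamino with piperidin-1-yl is therefore expected to leave this assay essentially unchanged, with a step of a 1.0-fold lower number from compound 3 to compound 4 (0.01 log units; within the scatter) of no size beyond the scatter. Compound 4 is thus estimated at 1000 nM, with a range from 500 nM to 2100 nM.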

Compound 4, half-maximal inhibitory concentration: 3460 nM
Beside the measured number, compound 4's estimate is 3.5-fold (0.54 log units) below it; the whole stated range lies below it.
By their numbers in this assay, from the lowest: compounds 3, 2 and 1 (each within the scatter of the next); then compound 4.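

In this assay, among these compounds, piperidin-1-yl on a saturated chain carbon bound to an aromatic carbon gives the only steps beyond the scatter at this place: a 3.4-fold higher number from compound 3 to compound 4 (0.53 log units; beyond the scatter), and a 3.0-fold higher number from compound 2 to compound 4 (0.47 log units; beyond the scatter). This place therefore responds to the choice of amine, although ethylamino and diethylamino remain within the scatter of each other. Nothing available accounts for the shift. The compounds shown leave open whether the ring itself or the larger group sets the step. A pyrrolidin-1-yl or morpholin-4-yl group at this place could help separate the two.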